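The source may report more compounds than this note shows. Statements on the series, on what has been measured and on what is new or still open speak of the compounds shown alone.

Measured so far in a functional assay on HT-29 cells (Homo sapiens) for cytotoxicity, read by sulforhodamine B assay; a higher number here means a weaker inhibitor of growth, a lower number a stronger inhibitor of growth:

- Compound 1 `CC1=CC[C@@H]([C@@](C)(O)CCCC(C)(C)NC=S)CC1`: 47900 nM
- Compound 2 `CC1=CC[C@@H]([C@@](C)(O)CCCC(C)(C)NC(=S)NN)CC1`: > 100000 nM (a limit of the assay, not a number)
- Compound 3 `COc1ccc(/C=N\NC(=S)NC(C)(C)CCC[C@](C)(O)[C@@H]2CC=C(C)CC2)cc1`: 35200 nM

Compound 1 gives 47900 nM and compound 3 gives 35200 nM, two values within the usual scatter of each other, so neither can be ranked above the other. Within the data shown here, those are the only two true numbers in the set, as the result for compound 2 is a limit.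

Compound 4 `CC1=CC[C@@H]([C@@](C)(O)CCCC(C)(C)NC(=S)N/N=C\c2cccc([N+](=O)[O-])c2)CC1` differs from compound 3 in one place. On a carbon with a double bond to nitrogen, 3-nitrophenyl stands in place of 4-methoxyphenyl: 3-nitrophenyl in place of 4-methoxyphenyl on a carbon with a double bond to nitrogen.

The measured steps bear on this change only indirectly. The first is an at least 2.0-fold higher number from compound 1 to compound 2 (0.31 log units; beyond the scatter), a change at the thiocarbonyl carbon. The second is an at least 2.8-fold lower number from compound 2 to compound 3 (0.45 log units; beyond the scatter), which added the group holding the aromatic ring. From the compounds shown here alone, both steps involve the limit, so their true sizes remain open. Neither exchanges one aromatic group for another, so the data give no direction for this swap in this assay.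

The expected change is none beyond the scatter, estimated as a 1.0-fold higher number from compound 3 to compound 4 (0.01 log units; within the scatter). The estimated value for compound 4 is 36000 nM, with an expected range from 16000 nM to 80000 nM.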

Compound 4, concentration for total growth inhibition: 57100 nM
Beside the measured number, compound 4's estimate is 1.6-fold (0.20 log units) below it; the range from low to high includes it.
By their numbers in this assay, from the lowest: compounds 3, 1 and 4 (each within the scatter of the next). At a limit, above all of these: compound 2.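

In this assay, among these compounds, the exchange of 3-nitrophenyl for 4-methoxyphenyl gives a 1.6-fold higher number from compound 3 to compound 4 (0.21 log units; within the scatter), so this is the first direct look at one aromatic group standing in for another on this carbon, and the two cannot be told apart. Compound 3 and compound 4 both give true numbers rather than a limit, which shows that, on a carbon with a double bond to nitrogen, two quite different substituted phenyl groups can be carried with no readable difference in this assay. Nothing measured for these compounds bears on why the two groups read alike.

The two groups differ both in what the ring carries and in where it carries it, so the pair cannot show which of those matters, or whether the two effects simply offset each other. From the compounds shown here alone, it also remains open whether a ring holding an amine or a carboxylic acid, a plain phenyl ring, or a saturated carbon chain in place of the ring would separate from compound 3 and compound 4 by more than the scatter.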